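The compounds below may be only part of what the source reports. "The series", "measured", "known", "first", "only" and "open" are said of these compounds alone.

In a functional assay on HT-29 cells (Homo sapiens) for inhibition, read by MTT assay, with a stated time of 120 h (a higher number here means a weaker inhibitor, a lower number a stronger inhibitor), three compounds have been measured:

- Compound 1 `CC1CN(C(=O)c2ccc(-c3ccc(NC(=O)Nc4ccc(Cl)c(C(F)(F)F)c4)cc3)cc2)CC(C)O1`: 2050 nM
- Compound 2 `O=C(/C=C/c1ccc(NC(=O)Nc2ccc(Cl)c(C(F)(F)F)c2)cc1)NC1CCC1`: 4430 nM
- Compound 3 `CC(NC(=O)/C=C/c1ccc(NC(=O)Nc2ccc(Cl)c(C(F)(F)F)c2)cc1)c1ccccc1`: 1060 nM

Of these three, compound 2 has the highest number and so is the weakest inhibitor in this assay. The next compound to be tested is compound 4 `CNC(=O)/C(C)=C/c1ccc(NC(=O)Nc2ccc(Cl)c(C(F)(F)F)c2)cc1`, which departs from compound 2 as follows: 2-(methylcarbamoyl)prop-1-en-1-yl in place of 2-(cyclobutylcarbamoyl)ethenyl on an aromatic carbon. In words, 2-(methylcarbamoyl)prop-1-en-1-yl stands in place of 2-(cyclobutylcarbamoyl)ethenyl on an aromatic carbon.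

For the measured compounds named here, only one measured step bears on this change. It is a 4.2-fold lower number from compound 2 to compound 3 (0.62 log units; beyond the scatter), a modest step in which 1-phenylethyl replaces cyclobutyl on an amide-type nitrogen. Compound 4 also loses the cyclobutyl group, so that step shows that a change at this nitrogen can move the number. Going by the values given here, it does not cover a methyl group there, and no measured compound carries the 2-(methylcarbamoyl)prop-1-en-1-yl group, so the guide is weak. The expected step is small, perhaps within the scatter, and tilted towards a higher number: a 1.5-fold higher number from compound 2 to compound 4 (0.17 log units; within the scatter). For compound 4 the estimated value is 6500 nM, with an expected range of 2200 nM to 19000 nM.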

Compound 4, half-maximal inhibitory concentration: > 50000 nM
Compound 4: no number, only a limit; the forecaster's own chance of this, stated with the estimate: 15%; middle value at least 7.6-fold (0.88 log units) away from the limit.
By their numbers in this assay, from the lowest: compounds 3 and 1 (each within the scatter of the next); then compound 2. At a limit, above all of these: compound 4.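

In this assay compound 4 gives only a limit, not a number: the limit of > 50000 nM in this assay, at which 1 of the 4 values shown sits.

Read as a single change, putting 2-(methylcarbamoyl)prop-1-en-1-yl in place of 2-(cyclobutylcarbamoyl)ethenyl on the aromatic carbon gives an at least 11-fold higher number from compound 2 to compound 4 (1.05 log units; beyond the scatter), a large step. For the compounds shown here, the one earlier step on this chain was a 4.2-fold lower number from compound 2 to compound 3 (0.62 log units; beyond the scatter), so until now a change here had only been seen to lower the number, and compound 4 shows that the same part of the molecule can also raise it sharply.

The new group differs from the old one in two respects at once, methyl in place of cyclobutyl on the amide nitrogen and the extra methyl of the prop-1-en-1-yl chain, and the compounds shown do not separate the share of each. Also open, as far as these compounds go, is how the number would respond to an amine or a carboxylic acid at the end of this chain, or to a longer alkyl chain on the amide nitrogen.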